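Chloro in Place of Hydrogen on the Shared Core

This account rests on a few compounds, and the source may have more. Where it says the series, first, only, none or still open, it means among the compounds named here.

Compound 1, `CS(=O)(=O)c1ccc(-c2[nH]ccc2-c2ccc(F)cc2)cc1`, is the starting point. In a functional assay on the whole organism with Rattus norvegicus as the target (on this read-out lower numbers stand for an effect already at smaller amounts and higher numbers for an effect only at larger amounts of compound), compound 1 gives only the limit of the measurement, > 100 mg/kg, so its standing is known as a bound and not as a number (the limit of > 100 mg/kg in this assay, at which 1 of the 3 values shown sits). Two measured steps leave from it. Compound 2, `CS(=O)(=O)c1ccc(-c2[nH]c(C(=O)C(F)(F)F)cc2-c2ccc(F)cc2)cc1`, carries (trifluoromethyl)carbonyl in place of hydrogen on an aromatic carbon and gives 19.4 mg/kg in this assay, a change of an at least 5.1-fold lower number from compound 1 to compound 2 (0.71 log units; beyond the scatter). Compound 3, `CS(=O)(=O)c1ccc(-c2[nH]c(S(C)(=O)=O)cc2-c2ccc(F)cc2)cc1`, carries methylsulfonyl in place of hydrogen on an aromatic carbon and gives 36.6 mg/kg; the step of an at least 2.7-fold lower number from compound 1 to compound 3 (0.43 log units; beyond the scatter) is likewise beyond the scatter. The two substituted compounds themselves differ by a 1.9-fold higher number from compound 2 to compound 3 (0.28 log units; within the scatter), which is within the scatter.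

Compound 4, `CS(=O)(=O)c1ccc(-c2[nH]c(Cl)cc2-c2ccc(F)cc2)cc1`, has not yet been measured. Its change from compound 1 is chloro in place of hydrogen on an aromatic carbon. Both measured steps at this same aromatic carbon lowered the number beyond the scatter, and chloro enters as a single heavy atom in place of hydrogen. A lower number than that of compound 1 is therefore expected, although the reference being a limit leaves the size uncertain. Compound 4 is estimated at 40 mg/kg, with a range from 15 mg/kg to 120 mg/kg. This estimate corresponds to an expected step of an at least 2.5-fold lower number from compound 1 to compound 4 (0.39 log units; beyond the scatter).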

Compound 4, dose for half-maximal effect: 0.5 mg/kg
Compound 4: the middle estimate sits 80-fold (1.90 log units) above what was measured, and the stated range ends above it.
By their numbers in this assay, from the lowest: compound 4; then compounds 2 and 3 (each within the scatter of the next). At a limit, above all of these: compound 1.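

In this assay, going by these compounds alone, the carbon next to the ring nitrogen proves able to carry a far larger change than the earlier compounds revealed: chloro in place of hydrogen gives an at least 200-fold lower number from compound 1 to compound 4 (2.30 log units; beyond the scatter) and so counts as a large step, whereas the two earlier steps at this carbon were known only as at least modest. The identity of the group at this carbon also matters more than compounds 2 and 3 could show, since those two lie within the scatter of each other, while chloro in place of methylsulfonyl gives a 73-fold lower number from compound 3 to compound 4 (1.86 log units; beyond the scatter) and chloro in place of (trifluoromethyl)carbonyl gives a 39-fold lower number from compound 2 to compound 4 (1.59 log units; beyond the scatter) as a further large step. Going by these compounds, compound 1 stands at a limit and not at a number, so the full size of the step from it stays unknown: the limit of > 100 mg/kg in this assay, at which 1 of the 4 values shown sits.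

The compounds shown hold chloro as their only group of 1 heavy atom at this carbon, so it remains open whether fluoro, bromo or methyl would give a similar number. They also leave open what a nitrile or an amine would do at the same carbon, and the data give no reason for the size of the chloro step.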